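Replacing the Methylsulfinyl Group of Compound 1 with Carboxy

The source may report more compounds than this note shows. Statements on the series, on what has been measured and on what is new or still open speak of the compounds shown alone.

Compound 1 `C[S+]([O-])c1c(F)c(N)c2c(=O)cc(-c3ccc(N)c(F)c3)oc2c1F`: 2500 nM
Compound 2 `COc1c(F)c(N)c2c(=O)cc(-c3ccc(N)c(F)c3)oc2c1F`: 100 nM

In a functional assay on MCF7 cells (Homo sapiens) for cytotoxicity, read by neutral red uptake, with a stated time of 3 days (a higher number here means a weaker inhibitor, a lower number a stronger inhibitor), compound 1 holds the highest of the two numbers; the step of a 25-fold lower number from compound 1 to compound 2 (1.40 log units; beyond the scatter) is the only one measured at this aromatic carbon of the shared core. Compound 3 `Nc1ccc(-c2cc(=O)c3c(N)c(F)c(C(=O)O)c(F)c3o2)cc1F` carries a change at the same carbon, (a group of 3 heavy atoms (1 carbon, 2 oxygen; no ring) in place of a group of 3 heavy atoms (1 carbon, 1 oxygen, 1 sulfur; no ring), on an aromatic carbon). Going by the values given here, the single measured step shows that exchanging the group here can move the number a great deal, yet it gives no guide to the direction for carboxy. Compound 3 is therefore expected to stay near compound 1, with a 1.2-fold higher number from compound 1 to compound 3 (0.08 log units; within the scatter) and a wide range, at 3000 nM (from 400 nM to 20000 nM).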

Compound 3, half-maximal inhibitory concentration: > 10000 nM
Compound 3 ended at the assay's limit (the forecaster's own chance of this, stated with the estimate: 15%); at least 3.3-fold (0.52 log units) between middle value and limit.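

In this assay compound 3 gives a limit and not a number: the limit of > 10000 nM in this assay, at which 1 of the 3 values shown sits. Carboxy moves the number the opposite way to methoxy at this aromatic carbon, with an at least 4.0-fold higher number from compound 1 to compound 3 (0.60 log units; beyond the scatter) and an at least 100-fold higher number from compound 2 to compound 3 (2.00 log units; beyond the scatter). The position therefore responds in both directions, and methoxy gives the lowest number of the three compounds.

As far as these compounds go, how far compound 3 lies past its limit remains unknown, so the full size of both steps stays open. The compounds shown also leave open whether an amine or an ethoxy group here would fall nearer compound 2 or compound 1.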